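The source may hold more compounds than are shown below. What is called first, only, known or untested is meant among the compounds shown, and "the series" means these compounds.

Values in an ADME assay on HeLa cells (Homo sapiens) for cytotoxicity, read by crystal violet staining, with a stated time of 72 h; on this read-out higher numbers stand for lower toxicity in this test and lower numbers for higher toxicity in this test:
- compound 1 `CCOC(=O)c1cc(CCCOc2ccc(-c3noc(C(F)(F)F)n3)cc2)on1` gives > 100000 nM, a limit
- compound 2 `CCNC(=O)c1cc(CCCOc2c(C)cc(-c3noc(C(F)(F)F)n3)cc2C)on1` gives > 100000 nM, a limit
- compound 3 `CN(C)C(=O)c1cc(CCCOc2ccc(-c3noc(C(F)(F)F)n3)cc2)on1` gives 28000 nM

Compound 1 has only a limit and no number, a position it shares with compound 2: the limit of > 100000 nM in this assay, at which 2 of the 3 values shown sit.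

Compound 4 `CCOC(=O)c1cc(CCCOc2ccc(-c3noc(C(F)(F)F)n3)cc2NC(C)=O)on1` keeps the core of compound 1 and carries one change: acetamido in place of hydrogen on an aromatic carbon. In words, this is acetamido in place of hydrogen on an aromatic carbon, ortho to a large group and meta to the 5-(trifluoromethyl)-1,2,4-oxadiazol-3-yl group.

Within the data shown here, only one measured step starts from compound 1: an at least 3.5-fold lower number from compound 1 to compound 3 (0.55 log units; beyond the scatter). That step puts dimethylamino in place of ethoxy on a carbonyl carbon, so it touches a different place and bears on this change only indirectly. It does show that a single change can bring this core down from the limit. Among the measured compounds shown here, no measured step covers acetamido on the aromatic carbon. For the measured compounds named here, with compound 3 as the only guide, a modest step toward lower numbers in this assay is expected, or none beyond the scatter.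

For compound 4 the expected value is 70000 nM, with an estimated range of 25000 nM to 100000 nM.

The estimate corresponds to an expected at least 1.4-fold lower number from compound 1 to compound 4 (0.15 log units; that floor lies within the scatter).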

Compound 4, half-maximal cytotoxic concentration: > 100000 nM
Compound 4: no number, only a limit; the forecaster's own chance of this, stated with the estimate: 50%; at least 1.4-fold (0.15 log units) between middle value and limit.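

Among these compounds, compound 1 and compound 4 both sit at a limit and carry no number in this assay, so no step between them can be read: the limit of > 100000 nM in this assay, at which 3 of the 4 values shown sit. The compounds shown leave open whether acetamido in place of hydrogen on the aromatic carbon shifts the value in this assay at all, and in which direction.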